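This account rests on a few compounds, and the source may have more. Where it says the series, first, only, none or still open, it means among the compounds named here.

Measured in a functional assay on HL-60 cells (Homo sapiens) for cytotoxicity, read by MTT assay, with a stated time of 48 h; a higher number here means a weaker inhibitor, a lower number a stronger inhibitor:

- Compound 1 `Oc1cccc(Nc2nc(-c3cccc(F)c3)nc3ccc(F)cc23)c1`: > 50000 nM (a limit, not a number)
- Compound 2 `Nc1ccccc1Nc1nc(-c2cccc(F)c2)nc2ccc(F)cc12`: 41300 nM

For the measured compounds named here, compound 2, at 41300 nM, holds the only actual number so far. The result for compound 1 is a limit. Compound 3 `Cc1ccc(Nc2nc(-c3cccc(F)c3)nc3ccc(F)cc23)cc1` keeps the shared core, with 4-methylphenyl in place of 2-aminophenyl on a nitrogen on an aromatic ring. Going by the values given here, the one measured step at this place, an at least 1.2-fold lower number from compound 1 to compound 2 (0.08 log units; that floor lies within the scatter), has a floor within the scatter, so it offers no sign of a large change. A step beyond the scatter is therefore not expected in this assay. The estimated step is a 1.1-fold lower number from compound 2 to compound 3 (0.04 log units; within the scatter). For compound 3 the expected value is 38000 nM, with an estimated range of 14000 nM to 90000 nM.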

Compound 3, half-maximal inhibitory concentration: > 50000 nM
Compound 3: a limit, no number (the forecaster's own chance of this, stated with the estimate: 45%); middle value at least 1.3-fold (0.11 log units) from the limit.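

Compound 3 gives a limit, not a number, in this assay. Putting 4-methylphenyl, with 0 hydrogen-bond donors, in place of 2-aminophenyl gives an at least 1.2-fold higher number from compound 2 to compound 3 (0.08 log units; that floor lies within the scatter) and so shows no gain in strength, though the true size of the step stays hidden. With a carbon-only substituted ring as well, this place has still produced no clearly lower number: the limit of > 50000 nM in this assay, at which 2 of the 3 values shown sit.

The step between compound 1 and compound 3 cannot be read, since both are limits. As far as these compounds go, whether a morpholine or a carboxylic acid on this nitrogen would give a clearly lower number stays open.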